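The compounds below may be only part of what the source reports. "The series", "measured", "known", "first", "only" and "open" are said of these compounds alone.

Of the compounds shown here, three sharing a fluorinated side chain have been measured in a physicochemical assay for lipophilicity, using the shake flask method, in phosphate buffer, measured as octanol-water partition, with a stated time of 30 min, at pH 7.4; on this read-out lower numbers stand for lower lipophilicity and higher numbers for higher lipophilicity. Compound 1 (`Cc1nccn1-c1cnc(NCc2c(F)ccc3c2CCO3)c2cn[nH]c(=O)c12`) gives 2.1, compound 3 (`Cc1ncccc1-c1cnc(NCc2c(F)ccc3c2CCO3)c2n[nH]c(=O)n12`) gives 2.5, and compound 2 (`Fc1ccc2c(c1CNc1ncc(Oc3ccccc3)c3nncn13)CCO2`) gives 3.5. Compound 2 therefore stands highest of the three, with compound 3 nearest to it and compound 1 furthest away, and both gaps lie beyond the usual scatter of repeat measurements.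

Compound 4 (`CN(C(=O)c1ccccc1)c1cnc(NCc2c(F)ccc3c2CCO3)n2cnnc12`) has not yet been measured. It keeps the core of compound 2 and changes one group: benzoyl(methyl)amino in place of phenoxy on an aromatic carbon. In short, benzoyl(methyl)amino takes the place of phenoxy on an aromatic carbon.

Within the data shown here, no measured pair here shows this swap, so any expectation is rough. Among the measured compounds shown here, the only guide is that compound 2 at 3.5 lies above both other measured compounds, so a moderate fall beyond the scatter is expected in this assay. The estimated change is a number 0.60 log units lower from compound 2 to compound 4 (beyond the scatter). For compound 4 the estimate is 2.9, with an expected range from 2.4 to 3.4.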

Compound 4, distribution coefficient: 2.4
The estimate for compound 4 lay 0.50 log units above the measured number; measured number inside the range.
By their numbers in this assay, from the lowest: compounds 1, 4 and 3 (each within the scatter of the next, the first and the last beyond it); then compound 2.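

In this assay, the swap at this aromatic carbon gives the only step shown between compounds that differ in one place: a number 1.10 log units lower from compound 2 to compound 4 (beyond the scatter), with benzoyl(methyl)amino in place of phenoxy. The read-out therefore responds to what sits at this position, on a six-membered aromatic ring with 2 nitrogen, even though both groups count one six-membered aromatic ring of carbon only and 1 hydrogen-bond acceptor, while the entering group has 10 heavy atoms against 7. Nothing available here accounts for the size or direction of this step.

Which part of benzoyl(methyl)amino goes with the lower number remains open, as this single swap cannot separate its carbonyl from its methyl. Going by these compounds, how an amine or a carboxylic acid at the same carbon would read in this assay is also open.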